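The source may report more compounds than this note shows. Statements on the series, on what has been measured and on what is new or still open speak of the compounds shown alone.

Measured so far:
- compound 1 `Fc1cccc(-c2nc(Nc3ccccc3Cl)c3cc(F)ccc3n2)c1` — > 50000 nM
- compound 2 `Oc1ccccc1Nc1nc(-c2cccc(F)c2)nc2ccc(F)cc12` — 46300 nM

In a functional assay on U-937 cells (Homo sapiens) for cytotoxicity, read by MTT assay, with a stated time of 48 h (a lower number here means a stronger inhibitor, a higher number a weaker inhibitor), compound 1 gives only a limit, > 50000 nM, so its position on the numbers is known only as that limit of > 50000 nM in this assay, at which 1 of the 2 values shown sits, and not as a value. Compound 2 gives a number, 46300 nM, in this assay. For the measured compounds named here, the one measured step, an at least 1.0-fold lower number from compound 1 to compound 2 (0.03 log units; that floor lies within the scatter), comes from hydroxy in place of chloro on an aromatic carbon and reads as no change beyond the scatter; with the starting point a limit, the step itself is only a floor.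

Compound 3 `Cc1ccccc1Nc1nc(-c2cccc(F)c2)nc2ccc(F)cc12` is the next variation at the same place: methyl in place of chloro on an aromatic carbon. Going by the values given here, the only step that bears on it is the hydroxy case above, which moved nothing that could be told apart from scatter. Among the compounds with values here, no step here reaches beyond the scatter, so no shift beyond the scatter is expected in this assay for compound 3 in either direction. Compound 3 is therefore estimated at 50000 nM, in a range of 20000 nM to 150000 nM, the expected step being a number no higher from compound 1 to compound 3 (the limit leaves the size open), with a real chance that only a limit is reported again.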

Compound 3, half-maximal inhibitory concentration: > 50000 nM
Compound 3 gave a limit, no number; the forecaster's own chance of this, stated with the estimate: 70%; the middle value lies on the limit itself.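

In this assay compound 3 gives > 50000 nM, a limit and not a number, so a carbon group at this place joins chloro without yielding a measurable value. Methyl in place of hydroxy gives an at least 1.0-fold higher number from compound 2 to compound 3 (0.03 log units; that floor lies within the scatter), a change that cannot be told apart from scatter, while the step between the two limits, from compound 1 to compound 3, cannot be read. Across chloro, hydroxy and methyl on this aromatic carbon, no readable step goes beyond the scatter, and the values shown gather at the top of the assay's range: the limit of > 50000 nM in this assay, at which 2 of the 3 values shown sit.

For the compounds shown here, still open is whether another group at this place, such as an amine, a carboxylic acid or a methoxy group, would give a number clearly lower than the one for compound 2, 46300 nM. From the compounds shown here alone, how far compound 1 and compound 3 truly lie from compound 2 also stays open, and the chloro-to-methyl change has no readable size.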